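Swapping the aryl group: from compound 2 to compound 3

The source may hold more compounds than are shown below. What is called first, only, known or untested is meant among the compounds shown, and "the series" means these compounds.

Compound 2 `COc1ccc(-c2ccc3c(NCCCNCc4ccco4)ccnc3c2)cc1` carries a 4-methoxyphenyl group, and in an ADME assay for permeability, using PAMPA, with a stated time of 30 min, at pH 7.4 (a lower number here means that the compound crosses the layer more slowly, a higher number that the compound crosses the layer faster), compound 2 gives 237 10^-6 cm/s. Compound 1 `Fc1ccc(-c2ccc3c(NCCCNCc4ccco4)ccnc3c2)cc1` has a fluoro group instead, and in this assay compound 1 gives 237 10^-6 cm/s. That one change produced no change at the digits printed from compound 1 to compound 2 (within the scatter). Compound 3 `c1coc(CNCCCNc2ccnc3cc(-c4cccc5ccccc45)ccc23)c1` alters the same aryl group: naphthalen-1-yl in place of 4-methoxyphenyl on an aromatic carbon. Among the compounds with values here, only the step between compound 1 and compound 2 bears on this, and it showed nothing beyond the scatter, so the step of a 1.0-fold lower number from compound 2 to compound 3 (0.01 log units; within the scatter) is expected to stay within the scatter in this assay. Compound 3 is therefore estimated at 230 10^-6 cm/s, with a range of 120 10^-6 cm/s to 420 10^-6 cm/s.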

Compound 3, apparent permeability: 237 10^-6 cm/s
Beside the measured number, compound 3's estimate is 1.0-fold (0.01 log units) below it; the measured number falls inside the stated range.
By their numbers in this assay, from the lowest: compounds 1, 2 and 3 (each within the scatter of the next).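

In this assay the position takes naphthalen-1-yl, with 2 six-membered aromatic rings of carbon only, and the result is no change at the digits printed from compound 2 to compound 3 (within the scatter) and likewise no change at the digits printed from compound 1 to compound 3 (within the scatter) as the read-out. The earlier step only exchanged one substituent on a single ring, whereas this one also adds a ring and removes the hydrogen-bond acceptor of 4-methoxyphenyl, and the values still stay level. No measurement shown accounts for this. Going by these compounds, all three compounds carry aromatic carbon rings here, so an amine or a carboxylic acid at this position remains open, as does a longer chain on the shared core.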